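A few compounds are considered here, and "the series" means these few. Any claim that something is new, unique, unknown or untested is made for them only; others in the source may bear on it.

Working notes on the series

The series is followed in a functional assay on the whole organism for inhibition, with Mus musculus as the target, at a dose of 10 mg/kg by the oral route; on this read-out higher numbers stand for more inhibition at the one dose given (going by the name of the read-out) and lower numbers for less inhibition. Compound 1 `CSc1ccc2c(c1)c(O)c(C(=S)N(C)c1ccccc1)c(=O)n2C` gives 32% in this assay. Compound 2 `CN1C(=O)/C(=C(/S)N(C)c2ccccc2)C(=O)c2cc(Cl)ccc21` gives 64%; 64% (2 entries) in this assay, recorded as two entries rather than one number. Compound 3 `COc1ccc(N(C)/C(S)=C2/C(=O)c3cc(Cl)ccc3N(C)C2=O)cc1` gives 45% in this assay. Of the two compounds with a single number, compound 3 stands highest, and its nearest neighbour is compound 1, which lies lower by a gap beyond the usual scatter; compound 2, with its two entries, is not ranked against compound 3 on a single number.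

The next compound, compound 4 `COc1cccc(N(C)/C(S)=C2/C(=O)c3cc(Cl)ccc3N(C)C2=O)c1`, is built from the same atoms as compound 3, joined differently: 3-methoxyphenyl in place of 4-methoxyphenyl on an amine nitrogen. Going by the values given here, no step between two measured compounds touches the same position, so nothing measured here tells how far such a move shifts this assay. Shuffling the methoxy group around the aromatic ring on the amine nitrogen is expected to leave this assay roughly where it stands, with no step beyond the scatter in either direction, so the expected step of no change at the digits printed from compound 3 to compound 4 (within the scatter) is essentially flat. Compound 4 is therefore estimated at 45% in this assay, within a range from 25% to 65%.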

Compound 4, a percentage reported as inhibition, in the whole organism at one dose (the size of the read-out at that dose, not a potency): 30%
The estimate for compound 4 lay 15 percentage points above the measured number; the measured number falls inside the stated range.
By their numbers in this assay, from the lowest: compounds 4 and 1 (each within the scatter of the next); then compound 3.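

Going by these compounds alone, the first step at this position shows that moving the methoxy group around the aromatic ring on the amine nitrogen is not neutral: in this assay the change to 3-methoxyphenyl in place of 4-methoxyphenyl gives a number 15 percentage points lower from compound 3 to compound 4 (beyond the scatter) and this lies beyond the scatter. The two groups have the same counts of heavy atoms, hydrogen-bond donors and hydrogen-bond acceptors, so those counts do not separate them, and the read-out here follows the placement of the methoxy group on the ring. Nothing available in these notes accounts for the step.

Compound 2, with a plain phenyl on the same amine nitrogen, stands at 64%; 64% (2 entries) as two entries, so steps to it cannot be read and the size of the effect of either methoxy placement against the plain phenyl remains unsettled. Also open, on these data alone, is whether an ethoxy group, a hydroxyl or a carboxylic acid in place of the methoxy group would show the same dependence on placement, and whether the 3-methoxyphenyl result holds on the core of compound 1.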